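Swapping a fluorobenzyl arm for a phenacyl arm

The source may hold more compounds than are shown below. What is called first, only, known or untested is meant among the compounds shown, and "the series" means these compounds.

Measured compounds:
- compound 1, `COc1ccc(-n2c(SCc3ccc(F)cc3)nnc2-c2cc(OC)c(OC)c(OC)c2)cc1`, gives 35000 nM
- compound 2, `COc1ccc(-n2c(SCC(=O)c3ccccc3)nnc2-c2cc(OC)c(OC)c(OC)c2)cc1`, gives > 60000 nM
- compound 3, `COc1cc(-c2nnc(SCc3ccc(F)cc3)n2-c2ccc(N(C)C)cc2)cc(OC)c1OC`, gives 46500 nM

All three were tested in a functional assay on PC-3 cells (Homo sapiens) for inhibition, read by MTT assay, with a stated time of 48 h; on this read-out higher numbers stand for weaker inhibition and lower numbers for stronger inhibition. Compound 1 gives 35000 nM. Compound 2 reaches only a limit of this assay, > 60000 nM, and no number. Compound 3 gives 46500 nM.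

The change from compound 1 to compound 2 is benzoyl in place of 4-fluorophenyl on a saturated chain carbon bound to a sulfur. It made a step of an at least 1.7-fold higher number from compound 1 to compound 2 (0.23 log units; that floor lies within the scatter); that step is counted from the limit (the limit of > 60000 nM in this assay, at which 1 of the 3 values shown sits), so its true size is open.

Compound 3 differs from compound 1 in its core: dimethylamino in place of methoxy on an aromatic carbon. This gave a step of a 1.3-fold higher number from compound 1 to compound 3 (0.12 log units; within the scatter).

Compound 4, `COc1cc(-c2nnc(SCC(=O)c3ccccc3)n2-c2ccc(N(C)C)cc2)cc(OC)c1OC`, has not yet been measured. It differs from compound 3 by benzoyl in place of 4-fluorophenyl on a saturated chain carbon bound to a sulfur. This is the same change as from compound 1 to compound 2, made on the core of compound 3. The place lines of the two changes agree word for word, so nothing around the place differs.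

Compound 4 is expected to give a step of a 1.6-fold higher number from compound 3 to compound 4 (0.21 log units; within the scatter) in this assay, resting on compound 3 at 46500 nM and on the step of an at least 1.7-fold higher number from compound 1 to compound 2 (0.23 log units; that floor lies within the scatter). Compound 4 is therefore estimated at 75000 nM, most likely reported as a limit again, with a range from 40000 nM to 160000 nM.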

Compound 4, half-maximal inhibitory concentration: 38600 nM
Compound 4: middle estimate off by 1.9-fold (0.29 log units), on the high side; measured number outside the range, below it.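

On the core of compound 3, putting benzoyl in place of 4-fluorophenyl gave a 1.2-fold lower number from compound 3 to compound 4 (0.08 log units; within the scatter) in this assay, so on this core the swap leaves no mark that can be told apart from repeat noise. This neither proves that the change carries over from one core to the other nor proves that it fails to, since compound 2 stands at a limit of the assay and gives no number: the same change on two cores in this assay, an at least 1.7-fold higher number (0.23 log units; that floor lies within the scatter) from compound 1 to compound 2 and a 1.2-fold lower number (0.08 log units; within the scatter) from compound 3 to compound 4; the limit leaves it open whether they differ The same holds when the pair is read the other way, with dimethylamino in place of methoxy on the benzoyl-bearing compounds giving an at least 1.5-fold lower number from compound 2 to compound 4 (0.19 log units; that floor lies within the scatter), so that this change also cannot be said to match or differ between the two arms: the same change on two cores in this assay, a 1.3-fold higher number (0.12 log units; within the scatter) from compound 1 to compound 3 and an at least 1.5-fold lower number (0.19 log units; that floor lies within the scatter) from compound 2 to compound 4; the limit leaves it open whether they differ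

On these data alone, with only these four compounds, the true size of any step that starts from compound 2 stays open, and so does the question of whether the two changes depend on each other at all. Also open, as far as these compounds go, is how the sulfur-linked arm would behave with a longer chain between the sulfur and the carbonyl, or with an amine or a carboxylic acid on its aromatic ring.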